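From a Butenamide to a Methylbutenamide on a Shared Core

A few compounds are considered here, and "the series" means these few. Any claim that something is new, unique, unknown or untested is made for them only; others in the source may bear on it.

Two compounds built on the same core, each carrying an unsaturated amide, have been measured in a functional assay on NCI-H1975 cells (Homo sapiens) for antiproliferative activity, read by MTT assay, with a stated time of 72 h; a higher number here means a weaker inhibitor, a lower number a stronger inhibitor. Compound 1, `COc1cc(N(C)CCN(C)C)c(NC(=O)/C=C\C(C)C)cc1Nc1nc(C)cc(-c2cn(C)c3ccccc23)n1`, gives 1230 nM in this assay. Compound 2, `CC/C=C\C(=O)Nc1cc(Nc2nc(C)cc(-c3cn(C)c4ccc(F)cc34)n2)c(OC)cc1N(C)CCN(C)C`, gives 10400 nM in this assay and so stands with the higher of the two numbers, the weaker inhibitor of the pair. Compound 1 and compound 2 differ in more than one place, so their two values alone do not tell which part of the difference carries the gap.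

Compound 3, `COc1cc(N(C)CCN(C)C)c(NC(=O)/C=C\C(C)C)cc1Nc1nc(C)cc(-c2cn(C)c3ccc(F)cc23)n1`, has not yet been measured. It differs from compound 2 in one place: methyl in place of hydrogen on a saturated chain carbon bound to a double-bonded chain carbon and a saturated chain carbon. After this change the amide chain of compound 3 matches that of compound 1, while the fluorine on the ring system of compound 2 remains.

Because compound 1 gives 1230 nM and compound 2 gives 10400 nM, a drop in the number is expected here. The expected step is a 3.5-fold lower number from compound 2 to compound 3 (0.54 log units; beyond the scatter). In this assay compound 3 is expected to give about 3000 nM, within a range from 1000 nM to 9000 nM.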

Compound 3, half-maximal inhibitory concentration: 8520 nM
Compound 3: the middle estimate sits 2.8-fold (0.45 log units) below what was measured; the range from low to high includes it.
By their numbers in this assay, from the lowest: compound 1; then compounds 3 and 2 (each within the scatter of the next).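

In this assay, the added methyl that turns ethyl into isopropyl on the amide chain has no effect that can be told apart from the scatter on the fluorinated core, with a 1.2-fold lower number from compound 2 to compound 3 (0.09 log units; within the scatter) as its step. With the 3-methylbut-1-en-1-yl chain held fixed, fluoro in place of hydrogen on an aromatic carbon gives a 6.9-fold higher number from compound 1 to compound 3 (0.84 log units; beyond the scatter) as a modest step that lies beyond the scatter. Among these three compounds, the fluoro change therefore accounts for most of the gap between compound 1 and compound 2, while the chain change does not separate compound 2 from compound 3. Nothing measured here explains why either change has the size it does.

On these data alone, it remains open whether ethyl and isopropyl would also match on the core without fluoro, since the chain step is known only with fluoro present. Also open is how a chloro or methoxy group on that aromatic carbon, or a longer chain or an amine at the end of the amide chain, would compare with the groups shown.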